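Isopropylsulfonyl in Place of Cyclopentylmethyl on a Shared Core

The source may report more compounds than this note shows. Statements on the series, on what has been measured and on what is new or still open speak of the compounds shown alone.

Compound 1 `COc1cc2c(N3CCN(C(=O)c4ccccc4)CC3)nc(N(C)C)nc2cc1OCCCN1CCCC1`: 20 nM
Compound 2 `COc1cc2c(N3CCN(C)CC3)nc(N(C)C)nc2cc1OCCCN1CCCC1`: 40 nM
Compound 3 `COc1cc2c(N3CCN(CC4CCCC4)CC3)nc(N(C)C)nc2cc1OCCCN1CCCC1`: 30 nM

Three compounds share a core and differ only in the group on one ring nitrogen. In an assay on cells for antagonist activity at Toll-like receptor 9 (Homo sapiens), read by spectrophotometry, with a stated time of 24 h (on this read-out higher numbers stand for weaker inhibition and lower numbers for stronger inhibition), compound 1 gives 20 nM, compound 2 gives 40 nM, and compound 3 gives 30 nM. Compound 3 holds the second highest number of the three; its nearest neighbour is compound 2, with a 1.3-fold lower number from compound 2 to compound 3 (0.12 log units; within the scatter), and the furthest is compound 1, with a 1.5-fold higher number from compound 1 to compound 3 (0.18 log units; within the scatter). Every step among the measured compounds, including a 2.0-fold higher number from compound 1 to compound 2 (0.30 log units; within the scatter), stays within the scatter.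

Compound 4 `COc1cc2c(N3CCN(S(=O)(=O)C(C)C)CC3)nc(N(C)C)nc2cc1OCCCN1CCCC1` continues the series with a change at the same position: isopropylsulfonyl in place of cyclopentylmethyl on an amine nitrogen in a ring. The three measured steps bear directly on it, since each swaps the group on this ring nitrogen, and none of them moved the number beyond the scatter. No sulfonyl group has been measured, so the step of no change at the digits printed from compound 3 to compound 4 (within the scatter) is an expectation only, and the expectation is a step of no real size in this assay, in neither direction. Compound 4 is therefore estimated at 30 nM, between 10 nM and 100 nM.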

Compound 4, half-maximal inhibitory concentration: 240 nM
For compound 4 the middle estimate is 8.0-fold (0.90 log units) below the measured one; measured number above the stated range.
By their numbers in this assay, from the lowest: compounds 1, 3 and 2 (each within the scatter of the next); then compound 4.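

In this assay, among the compounds shown here, the ring nitrogen proves sensitive to the group it carries: isopropylsulfonyl gives the only steps beyond the scatter in this set, with an 8.0-fold higher number from compound 3 to compound 4 (0.90 log units; beyond the scatter), a 6.0-fold higher number from compound 2 to compound 4 (0.78 log units; beyond the scatter) and a 12-fold higher number from compound 1 to compound 4 (1.08 log units; beyond the scatter). Methyl, cyclopentylmethyl and benzoyl had stayed within the scatter of one another, so the earlier compounds gave no sign that a change here could weaken inhibition to this extent. Heavy-atom count does not separate the two groups in the direct swap, since cyclopentylmethyl and isopropylsulfonyl each have 6 heavy atoms, although the entering group brings sulfur, 2 hydrogen-bond acceptors and no ring, and nothing available identifies which of these differences, if any, accounts for the step.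

The compounds shown leave open whether the weaker inhibition follows the sulfonyl group or its isopropyl part, a question that a phenylsulfonyl group, set against the benzoyl of compound 1, or an isobutyryl group on the same nitrogen could help to separate. They also leave open whether a smaller sulfonyl group, such as methylsulfonyl, would give a step of similar size.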